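Fluorine position on the aryl ring: stability notes

The source may hold more compounds than are shown below. What is called first, only, known or untested is meant among the compounds shown, and "the series" means these compounds.

Three compounds of the shared core have numbers in an ADME assay (liver) for metabolic stability, with Liver microsome (Homo sapiens) as the target, read by LC-MS, using microsomes, with a stated time of 1 h, tested at 5 uM; a higher number here means that more of the compound is left, a lower number that less of the compound is left. Compound 1 `COc1cc(OC)cc(N2CCN(C(=O)c3oc(C)nc3-c3cccc(F)c3)CC2)c1` gives 11.3% in this assay. Compound 2 `Cc1nc(-c2ccccc2F)c(C(=O)N2CCN(c3cc(Cl)cc(Cl)c3)CC2)o1` gives 82.3% in this assay. Compound 3 `Cc1nc(-c2ccccc2)c(C(=O)N2CCN(c3cccc(C#N)c3)CC2)o1` gives 8% in this assay. Compound 1 and compound 3 sit within the scatter of each other, so no order between them can be claimed; compound 2 stands clearly higher than compound 1, beyond the scatter. Compound 2 differs from compound 1 in more than one place, so nothing can be said about which part of that difference matters.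

Compound 4 `COc1cc(OC)cc(N2CCN(C(=O)c3oc(C)nc3-c3ccc(F)cc3)CC2)c1` is not yet measured. Its difference from compound 1 is 4-fluorophenyl in place of 3-fluorophenyl on an aromatic carbon. Within the data shown here, no step between two measured compounds is known that changes only this, so the expectation rests on the single number for compound 1 and on compound 3 lying close to it.

The step of a number 0.7 percentage points higher from compound 1 to compound 4 (within the scatter) is expected to be small, not beyond the scatter, in no clear direction. Compound 4 is expected to give about 12% in this assay, with a range from 3% to 30%.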

Compound 4, percent of the compound remaining: 12.9%
Estimate against measurement, compound 4: 0.9 percentage points below; low and high end bracket the measured number.
By their numbers in this assay, from the lowest: compounds 3, 1 and 4 (each within the scatter of the next); then compound 2.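

Among these compounds, the step of a number 1.6 percentage points higher from compound 1 to compound 4 (within the scatter) is the first single-place comparison, and it concerns only where the fluorine sits on this aryl ring. In this assay, with the rest of compound 1 held fixed, 4-fluorophenyl and 3-fluorophenyl on this aromatic carbon cannot be told apart, so this change gives no handle on the number. Nothing measured here bears on the reason for this result.

The compounds shown leave open whether a different kind of group on this phenyl ring, such as an amine or a carboxylic acid, would move the number beyond the scatter. Among the compounds shown here, they also leave open which of its several differences sets compound 2 apart, as no single-place step connects it to the others.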